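The compounds below may be only part of what the source reports. "The series", "measured", "known", "first", "only" and "open" are said of these compounds alone.

Series so far, all in a functional assay on NCI/ADR cells (Homo sapiens) for cytotoxicity, read by sulforhodamine B assay (on this read-out higher numbers stand for weaker inhibition of growth and lower numbers for stronger inhibition of growth), with these results:
compound 1 `CC1=CC[C@@H]([C@@](C)(O)CCCC(C)(C)NC=S)CC1` gives 16700 nM
compound 2 `CC1=CC[C@@H]([C@@](C)(O)CCCC(C)(C)NC(=S)N/N=C\c2ccc(C)cc2)CC1` gives 6510 nM
compound 3 `CC1=CC[C@@H]([C@@](C)(O)CCCC(C)(C)NC(=S)N/N=C\c2ccc(N(C)C)cc2)CC1` gives 25200 nM

Compound 2 has the lowest number of the three, and its gaps to compound 1 and compound 3 both lie beyond the scatter. Next in line is compound 4 `CC1=CC[C@@H]([C@@](C)(O)CCCC(C)(C)NC(=S)N/N=C(/C)c2ccccc2)CC1`, still unmeasured, which differs from compound 2 by a group of 9 heavy atoms (8 carbon, 1 nitrogen; one six-membered aromatic ring of carbon only) in place of a group of 9 heavy atoms (8 carbon, 1 nitrogen; one six-membered aromatic ring of carbon only), on an amide-type nitrogen and keeps the same atoms, joined differently.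

Within the data shown here, only one measured step bears on this part of the molecule: a 3.9-fold higher number from compound 2 to compound 3 (0.59 log units; beyond the scatter), a modest rise. That step is a different kind of change, so it gives a scale more than a direction. All three numbers also lie close together, and compound 2 sits at the low end. A small move towards a higher number is therefore expected, probably not beyond the scatter, and a drop cannot be excluded.

The expected change is a 1.4-fold higher number from compound 2 to compound 4 (0.14 log units; within the scatter) in this assay on this estimate. For compound 4 the estimated value is 9000 nM, with an expected range from 3500 nM to 25000 nM and no tighter claim.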

Compound 4, concentration for 50% growth inhibition: 750 nM
Beside the measured number, compound 4's estimate is 12-fold (1.08 log units) above it; measured number outside the range, below it.
By their numbers in this assay, from the lowest: compound 4; then compound 2; then compounds 1 and 3 (each within the scatter of the next).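

In this assay, joining the same atoms differently in the group on the amide-type nitrogen gives an 8.7-fold lower number from compound 2 to compound 4 (0.94 log units; beyond the scatter), so this place responds to how the atoms are joined and not only to which atoms are present. The earlier change at this end of the molecule, a 3.9-fold higher number from compound 2 to compound 3 (0.59 log units; beyond the scatter), ran the other way, so changes to this group can move the number in either direction. Nothing on hand explains the drop seen with compound 4.

From the compounds shown here alone, whether the lower number holds when a longer chain or a carboxylic acid is placed in this group remains open. Going by these compounds, it also remains open whether an amine on the aromatic ring of compound 4 would keep the number low.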